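The source may report more compounds than this note shows. Statements on the series, on what has been measured and on what is new or still open speak of the compounds shown alone.

Working notes on the series. Compound 1 `CCCNc1nc(C(C)c2c(F)cccc2F)c(C)c(=O)[nH]1` is tested in an ADME assay on MT4 cells (Homo sapiens) for cytotoxicity, read by MTT assay, with a stated time of 4 days (a lower number here means that less compound is tolerated, a higher number that more compound is tolerated), where compound 1 gives 35000 nM. Compound 2 `Cc1c(Cc2c(F)cccc2F)nc(N(C)c2ccccc2)[nH]c1=O` reaches only a limit in this assay, so for compound 2 the value > 73000 nM is not a number; it sits at the limit of > 73000 nM in this assay, at which 1 of the 2 values shown sits. Among the measured compounds shown here, no step between measured compounds is available. Compound 3 `Cc1c(Cc2c(F)cccc2F)nc(N2CCN(C)CC2)[nH]c1=O` carries the change (4-methylpiperazin-1-yl in place of methyl(phenyl)amino on an aromatic carbon). With compound 2 known only as a limit, the size of the step cannot be fixed from the data; the step of an at least 1.2-fold lower number from compound 2 to compound 3 (0.08 log units; that floor lies within the scatter) is expected to be small or none beyond the scatter. Compound 3 is estimated at 60000 nM, within 25000 nM to 150000 nM.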

Compound 3, half-maximal cytotoxic concentration: > 75000 nM
Compound 3: no number, only a limit (the forecaster's own chance of this, stated with the estimate: 50%); at least 1.2-fold (0.09 log units) between middle value and limit.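

Among the compounds shown here, compound 2 and compound 3 are both known only as limits, and no step between them can be read. The compounds shown leave open whether 4-methylpiperazin-1-yl in place of methyl(phenyl)amino changes the tolerated concentration at all.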